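Three hydroxyphenyl-pyridines and a fourth still to test

This account rests on a few compounds, and the source may have more. Where it says the series, first, only, none or still open, it means among the compounds named here.

Measured so far:
compound 1, `Oc1cccc(-c2cc(-c3ccccc3O)cc(-c3cccc(O)c3)n2)c1`: 5150 nM
compound 2, `Oc1cccc(-c2cc(-c3cccc(O)c3)nc(-c3cccc(O)c3)c2)c1`: 3950 nM
compound 3, `Oc1ccc(-c2cc(-c3ccccc3O)cc(-c3ccccc3O)n2)cc1`: 8240 nM

All three were tested in a functional assay on HCT-15 cells (Homo sapiens) for cytotoxicity, read by CCK-8 assay, with a stated time of 4 days; on this read-out higher numbers stand for weaker inhibition and lower numbers for stronger inhibition. Compound 1 gives 5150 nM in this assay, compound 2 gives 3950 nM, and compound 3 gives 8240 nM. Compounds 1 and 2 share a core and differ by one change, (3-hydroxyphenyl in place of 2-hydroxyphenyl on an aromatic carbon). That change made a 1.3-fold lower number from compound 1 to compound 2 (0.12 log units; within the scatter). The difference between the cores of compound 1 and compound 3 is not broken down here; their numbers lie within the scatter of each other, while the numbers of compound 3 and compound 2 lie beyond it.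

Compound 4, `Oc1ccc(-c2cc(-c3cccc(O)c3)cc(-c3ccccc3O)n2)cc1`, has not yet been measured. It is related to compound 3 by 3-hydroxyphenyl in place of 2-hydroxyphenyl on an aromatic carbon. Within the data shown here, this is the same kind of change as the one from compound 1 to compound 2, not the same: there the place was meta to two 3-hydroxyphenyl groups, here it is meta to a 2-hydroxyphenyl group and meta to a 4-hydroxyphenyl group, in both cases opposite the ring nitrogen.

The step from compound 3 to compound 4 is expected to be a 1.3-fold lower number from compound 3 to compound 4 (0.10 log units; within the scatter), because the same kind of change gave a 1.3-fold lower number from compound 1 to compound 2 (0.12 log units; within the scatter). Among the measured compounds shown here, with only one earlier example, and that one within the scatter, the expectation is loose. Compound 4 is expected to give 6500 nM, with a likely range from 3000 nM to 14000 nM.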

Compound 4, half-maximal inhibitory concentration: > 50000 nM
Compound 4 ended at the assay's limit; the forecaster's own chance of this, stated with the estimate: 5%; middle value at least 7.6-fold (0.88 log units) away from the limit.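

In this assay compound 4 gives > 50000 nM, which is a limit of the assay and not a number. Putting 3-hydroxyphenyl in place of 2-hydroxyphenyl, opposite the ring nitrogen, gave an at least 6.0-fold higher number from compound 3 to compound 4 (0.78 log units; beyond the scatter), so the small effect seen on the first core did not carry over to the second: the same change on two cores in this assay, a 1.3-fold lower number (0.12 log units; within the scatter) from compound 1 to compound 2 and an at least 6.0-fold higher number (0.78 log units; beyond the scatter) from compound 3 to compound 4, at least 7.9-fold (0.89 log units) apart, beyond the scatter of two such steps These two pairs show that, among the compounds here, the result of this change on one core did not predict its result on the other, but they do not show why the two cores differ, and the limit leaves the full size of the step from compound 3 unknown.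

From the compounds shown here alone, it remains open whether the large step belongs to the particular mix of hydroxyphenyl groups around the changed place, here a 2-hydroxyphenyl group and a 4-hydroxyphenyl group, and a further pair with the same change on another core would help to test this. Going by these compounds, it is also open how either core would respond if an amine or a carboxylic acid stood in place of the hydroxyl group on the changed ring.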